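Swapping a Pyridine Tail for a Plain Propyl Chain

A few compounds are considered here, and "the series" means these few. Any claim that something is new, unique, unknown or untested is made for them only; others in the source may bear on it.

Compound 1 `COc1ccc2c(c1)NC(=O)CN2c1nc(NCCCO)nc2ccccc12`: 4.92 nM
Compound 2 `COc1ccc2c(c1)NC(=O)CN2c1nc(COCCCC(=O)NO)nc2ccccc12`: 307 nM
Compound 3 `COc1ccc2c(c1)NC(=O)CN2c1nc(NCc2ccncc2)nc2ccccc12`: 7.5 nM

These three compounds share one core and differ only in the group attached to it. In a functional assay on KB cells (Homo sapiens) for inhibition, read by sulforhodamine B assay, with a stated time of 48 h (on this read-out lower numbers stand for stronger inhibition of growth and higher numbers for weaker inhibition of growth), compound 3 gives 7.5 nM, the second highest of the three numbers; its nearest neighbour is compound 1, with a 1.5-fold higher number from compound 1 to compound 3 (0.18 log units; within the scatter), and its furthest is compound 2, with a 41-fold lower number from compound 2 to compound 3 (1.61 log units; beyond the scatter).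

Compound 4 `CCCCNc1nc(N2CC(=O)Nc3cc(OC)ccc32)c2ccccc2n1` has not yet been measured. It differs from compound 3 by propyl in place of pyridin-4-yl on a saturated chain carbon bound to a nitrogen on an aromatic ring.

Among the compounds with values here, only one measured step changes the same place, the step from compound 1 to compound 3, where a 1.5-fold higher number from compound 1 to compound 3 (0.18 log units; within the scatter), a change within the scatter. The two large steps, a 62-fold higher number from compound 1 to compound 2 (1.80 log units; beyond the scatter) and a 41-fold lower number from compound 2 to compound 3 (1.61 log units; beyond the scatter), involve a different part of the molecule and do not speak to a swap on the chain carbon. With a tail swap at the same place having left the number essentially unchanged, the expectation for compound 4 is a step of no more than the scatter, a 1.1-fold higher number from compound 3 to compound 4 (0.03 log units; within the scatter). Compound 4 is therefore estimated at 8 nM, with a range from 3 nM to 25 nM.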

Compound 4, concentration for 50% growth inhibition: 5.25 nM
Beside the measured number, compound 4's estimate is 1.5-fold (0.18 log units) above it, and the stated range covers the measured number.
By their numbers in this assay, from the lowest: compounds 1, 4 and 3 (each within the scatter of the next); then compound 2.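

In this assay, propyl in place of pyridin-4-yl gives a 1.4-fold lower number from compound 3 to compound 4 (0.15 log units; within the scatter), and methyl in place of hydroxy at the chain end gives a 1.1-fold higher number from compound 1 to compound 4 (0.03 log units; within the scatter), so neither the aromatic ring nor the terminal hydroxy is needed to keep the number at this position within the scatter. Within the data shown here, the only large step here is a 58-fold lower number from compound 2 to compound 4 (1.77 log units; beyond the scatter), where butylamino stands in place of (3-(hydroxycarbamoyl)propoxy)methyl on an aromatic carbon; that swap replaces the whole group, so it cannot be pinned on any one feature of it. Nothing available explains why the tails of compound 1, compound 3 and compound 4 give such similar numbers.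

These compounds leave open how far this tolerance extends, for instance to a much longer chain such as octyl, or to a carboxylic acid or a primary amine at the chain end. As far as these compounds go, it also remains open whether any tail is needed at all, which a plain unsubstituted amine on the same aromatic carbon would help to show.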